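Chloro to Bromo on a Long Chain: Cytotoxicity Estimate

A few compounds are considered here, and "the series" means these few. Any claim that something is new, unique, unknown or untested is made for them only; others in the source may bear on it.

Compound 1, `O=c1[nH]c(=O)n([C@H]2C[C@H](O)[C@@H](CO)O2)cc1C#CCCCCCCCCCCl`: 200000 nM
Compound 2, `O=c1[nH]c(=O)n([C@H]2C[C@H](O)[C@@H](CO)O2)cc1C#CCCCCCCCCCBr`: 50000 nM
Compound 3, `O=c1nc2oc(CCCCCCCCCCl)cc2cn1[C@H]1C[C@H](O)[C@@H](CO)O1`: > 200000 nM

The three compounds above were tested in a functional assay for cytotoxicity, read by microscopy; on this read-out higher numbers stand for lower toxicity in this test and lower numbers for higher toxicity in this test. Compound 1 gives 200000 nM in this assay, and compound 2 gives 50000 nM. The step between them, (bromo in place of chloro on a saturated chain carbon, nine bonds along the chain from a triple-bonded carbon), produced a 4.0-fold lower number from compound 1 to compound 2 (0.60 log units; beyond the scatter).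

Compound 3 carries a different core; the difference between the two cores is not broken down here. For compound 3 this assay reports only a limit, > 200000 nM, and not a number. This is the limit of > 200000 nM in this assay, at which 1 of the 3 values shown sits.

Compound 4, `O=c1nc2oc(CCCCCCCCCBr)cc2cn1[C@H]1C[C@H](O)[C@@H](CO)O1`, has not yet been measured in this assay. It differs from compound 3 by bromo in place of chloro on a saturated chain carbon, nine bonds along the chain from an aromatic carbon. Within the data shown here, this is the same kind of change as the one from compound 1 to compound 2, though the place differs: in the first pair the saturated chain carbon sits nine bonds along the chain from a triple-bonded carbon, in the second pair nine bonds along the chain from an aromatic carbon.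

Setting the earlier step beside it, compound 4 is expected to show an at least 2.0-fold lower number from compound 3 to compound 4 (0.30 log units; that floor lies within the scatter) in this assay, resting on the step of a 4.0-fold lower number from compound 1 to compound 2 (0.60 log units; beyond the scatter). Since compound 3 gives only a limit, the starting point is uncertain, and compound 4 may itself return a limit. The estimate for compound 4 in this assay is 100000 nM, with a range from 30000 nM to 400000 nM.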

Compound 4, minimum cytotoxic concentration: > 200000 nM
Compound 4: no number, only a limit; the forecaster's own chance of this, stated with the estimate: 50%; middle value at least 2.0-fold (0.30 log units) away from the limit.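

In this assay compound 4 gives > 200000 nM, which is a limit and not a number. Compound 3 also gives only a limit, so no step can be read between compound 3 and compound 4, because both sit at the same limit: the limit of > 200000 nM in this assay, at which 2 of the 4 values shown sit.

The compounds shown leave open whether bromo in place of chloro changes the read-out on the core of compound 3 as it does on the core of compound 1.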